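Swapping the hydroxyphenyl for a methylphenyl on the shared core

This account rests on a few compounds, and the source may have more. Where it says the series, first, only, none or still open, it means among the compounds named here.

compound 1 `O=C1CSC(c2cccc(O)c2)N1CCN1CCCCC1`: 100%
compound 2 `COc1ccccc1C1SCC(=O)N1CCN1CCCCC1`: 67%

In an ADME assay on Vero cells (Chlorocebus sabaeus) for cytotoxicity, read by neutral red uptake, tested at 394 ug/mL (a lower number here means a stronger effect, a higher number a weaker effect of the compound at the concentration tested), compound 1 gives 100%, the highest of the two numbers measured, that is, the weakest effect on the cells. Compound 2 gives 67% in this assay, lower by more than the usual scatter, so compound 2 acts more strongly on the cells. Compound 3 `Cc1ccc(C2SCC(=O)N2CCN2CCCCC2)cc1` has not yet been measured. It differs from compound 1 in one place: 4-methylphenyl in place of 3-hydroxyphenyl on a saturated ring carbon. Going by the values given here, no step between two measured compounds matches this change, so there is no direct guide to its size. Because compound 2, whose aryl group also carries no hydrogen-bond donor, gives 67%, a downward step is expected, and the step from compound 1 to compound 3 is estimated as a number 20 percentage points lower from compound 1 to compound 3 (beyond the scatter), of a size that may just exceed the scatter. Compound 3 is expected to give about 80%, within a range from 55% to 100%.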

Compound 3, a percentage reported as activity, at one concentration (the size of the read-out at that concentration, not a potency): 51%
Beside the measured number, compound 3's estimate is 29 percentage points above it; the whole stated range lies above it.
By their numbers in this assay, from the lowest: compound 3; then compound 2; then compound 1.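

Replacing 3-hydroxyphenyl with 4-methylphenyl on this saturated ring carbon in this assay gives a number 49 percentage points lower from compound 1 to compound 3 (beyond the scatter) and is a large step, so this position can strongly change how the compound acts on the cells. Going by these compounds alone, it is the first step measured here between two compounds that differ in one place, and it shows that a change in this aryl group alone can shift the number well past the usual scatter. No measurement shown explains the size or direction of this step.

This single step removes the hydroxyl and adds the methyl together, and the two contributions cannot be told apart. From the compounds shown here alone, it also remains open how the number would respond to an aryl group carrying an amine or a carboxylic acid at this position.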